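From 1H-imidazol-1-yl to dimethylamino in compound 4

The source may report more compounds than this note shows. Statements on the series, on what has been measured and on what is new or still open speak of the compounds shown alone.

- compound 1 `COC(=O)N(C)CC#CCN(C)C`: > 30 mg/kg
- compound 2 `COC(=O)N(C)C(C)C#CCN1CCCC1`: > 100 mg/kg
- compound 3 `COC(=O)N(C)C(C)C#CCn1ccnc1`: > 100 mg/kg
- compound 4 `COC(=O)N(C)C(C)C#CCN(C)C`: not yet measured

Going by the values given here, in a functional assay on the whole organism for antagonist activity, with Mus musculus as the target (a higher number here means that more compound is needed for the effect, a lower number that less compound is needed), no compound has yet given a number. Compound 1 gives > 30 mg/kg, which is a limit. Compound 2 gives > 100 mg/kg, also a limit. Compound 3 stands at > 100 mg/kg, again a limit.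

The change to compound 4 is dimethylamino in place of 1H-imidazol-1-yl on a saturated chain carbon bound to a triple-bonded carbon. Among the compounds with values here, the only measured step bearing on it is a step that the two limits leave unreadable from compound 2 to compound 3, so no size can be taken from it. No step beyond the scatter is therefore expected in this assay, in either direction. The expected step is a number no higher from compound 3 to compound 4 (the limit leaves the size open). For compound 4 the estimate is 100 mg/kg, with an expected range of 30 mg/kg to 300 mg/kg.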

Compound 4, dose for half-maximal effect: > 100 mg/kg
Compound 4 was reported as a limit (the forecaster's own chance of this, stated with the estimate: 75%); the middle value lies on the limit itself.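

In this assay compound 4 gives > 100 mg/kg, which is a limit. Going by these compounds alone, compound 1, compound 2 and compound 3 also carry only limits, so no step to compound 4 can be read. The compounds shown leave open how dimethylamino, pyrrolidin-1-yl and 1H-imidazol-1-yl rank, and whether any of the four reaches a measurable dose for half-maximal effect.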